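Removing a Methyl from the Core: Compound 4 Expected

The source may report more compounds than this note shows. Statements on the series, on what has been measured and on what is new or still open speak of the compounds shown alone.

Measured so far:
Compound 1, `COc1cccc(/C=C/C(=O)c2c(OC)cc(OC)cc2OC)c1`, gives 8900 nM.
Compound 2, `COc1cc(OC)c(C(=O)/C=C/c2ccc(Cl)cc2)c(OC)c1`, gives 12700 nM.
Compound 3, `COc1cc(OC)c(C(=O)/C=C/c2ccccc2SC)c(OC)c1`, gives 14100 nM.

These three numbers come from a functional assay on Huh-7 cells (Homo sapiens) for cytotoxicity, with a stated time of 48 h; on this read-out lower numbers stand for stronger inhibition and higher numbers for weaker inhibition. Compound 3 sits alongside the other two: the step of a 1.6-fold higher number from compound 1 to compound 3 (0.20 log units; within the scatter) and the step of a 1.1-fold higher number from compound 2 to compound 3 (0.05 log units; within the scatter) both stay within the scatter, as does a 1.4-fold higher number from compound 1 to compound 2 (0.15 log units; within the scatter), so the three compounds cannot be told apart on these numbers.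

Compound 4, `COc1cc(O)c(C(=O)/C=C/c2ccccc2SC)c(OC)c1`, differs from compound 3 by hydrogen in place of methyl on an oxygen on an aromatic ring. Among the measured compounds shown here, every measured step changed the ring at the far end of the chain; none touched an oxygen on the core, so no measured step bears directly on this change. With nothing to point either way, compound 4 is expected to sit close to compound 3, and the estimated step of a 1.6-fold lower number from compound 3 to compound 4 (0.19 log units; within the scatter) should not exceed the scatter. Compound 4 is therefore estimated at 9000 nM, expected between 2500 nM and 30000 nM.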

Compound 4, half-maximal inhibitory concentration: 16600 nM
For compound 4 the middle estimate is 1.8-fold (0.27 log units) below the measured one, within the range that was stated.
By their numbers in this assay, from the lowest: compounds 1, 2, 3 and 4 (each within the scatter of the next).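

Among the compounds shown here, this is the first change on the core rather than on the ring at the far end of the chain. In this assay going from methoxy to hydroxy on the aromatic ring gives a 1.2-fold higher number from compound 3 to compound 4 (0.07 log units; within the scatter) and stays within the scatter, so compound 3 and compound 4 cannot be told apart, and with 2-(methylsulfanyl)phenyl at the far end, this methyl can give way to hydrogen without a readable shift. No measurement at hand offers an explanation for this result.

Still open, going by these compounds, is whether a longer chain on this oxygen, such as ethoxy, or an amine in place of methoxy, would move the number beyond the scatter. Also open, on these data alone, is whether the other methoxy groups on the core allow the same change, and whether it reads alike with 4-chlorophenyl or 3-methoxyphenyl at the far end.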